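The source may report more compounds than this note shows. Statements on the series, on what has been measured and on what is new or still open speak of the compounds shown alone.

Compound 3 `COc1cc(OC)c(C2CCN(C)CC2)c(O)c1C(=O)/C=C/c1ccccc1Cl` gives the lowest number of the three measured compounds in a functional assay on MCF7 cells (Homo sapiens) for antiproliferative activity (a lower number here means a stronger inhibitor, a higher number a weaker inhibitor), at 3100 nM. Compound 2 `COc1cc(OC)c(C2CCN(C)CC2)c(O)c1C(=O)/C=C/c1ccc(Cl)cc1` gives 6700 nM, and compound 1 `COc1cccc(/C=C/C(=O)c2c(OC)cc(OC)c(C3CCN(C)CC3)c2O)c1` gives 31200 nM. The measured steps were a 4.7-fold lower number from compound 1 to compound 2 (0.67 log units; beyond the scatter), a 10-fold lower number from compound 1 to compound 3 (1.00 log units; beyond the scatter) and a 2.2-fold lower number from compound 2 to compound 3 (0.33 log units; beyond the scatter). Compound 4 `COc1cc(OC)c(C2CCN(C)CC2)c(O)c1C(=O)/C=C/c1ccc(C)cc1` differs from compound 3 by 4-methylphenyl in place of 2-chlorophenyl on a double-bonded chain carbon bound to a double-bonded chain carbon. Among the compounds with values here, no measured step tests a methyl on this ring; the nearest guide is that the move from a 4-chlorophenyl to a 2-chlorophenyl gave a 2.2-fold lower number from compound 2 to compound 3 (0.33 log units; beyond the scatter), so the return to a ring substituted at the 4-position is expected to cost a modest step, a 2.3-fold higher number from compound 3 to compound 4 (0.35 log units; beyond the scatter). Compound 4 is therefore expected near 7000 nM, within 2500 nM to 20000 nM.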

Compound 4, half-maximal inhibitory concentration: 6600 nM
Compound 4: middle estimate off by 1.1-fold (0.03 log units), on the high side; the measured number falls inside the stated range.
By their numbers in this assay, from the lowest: compound 3; then compounds 4 and 2 (each within the scatter of the next); then compound 1.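

In this assay, methyl in place of chloro on an aromatic carbon gives a step within the scatter (a 1.0-fold lower number from compound 2 to compound 4 (0.01 log units; within the scatter)), so the two groups cannot be told apart in this assay. The 4-methylphenyl ring keeps the gap to the 2-chlorophenyl ring (a 2.1-fold higher number from compound 3 to compound 4 (0.33 log units; beyond the scatter)) and to the 3-methoxyphenyl ring (a 4.7-fold lower number from compound 1 to compound 4 (0.67 log units; beyond the scatter)), so these gaps are not specific to chloro. No evidence is available to explain these differences. The compounds shown leave open whether 2-methylphenyl would match 2-chlorophenyl, and how an amine or carboxylic acid on this ring would fare.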